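Sulfonamide-linked azulene acids: isopropyl on a longer chain

The source may report more compounds than this note shows. Statements on the series, on what has been measured and on what is new or still open speak of the compounds shown alone.

Measured compounds in a functional assay (thoracic aorta) for inhibition, with Rattus norvegicus as the target; on this read-out higher numbers stand for weaker inhibition and lower numbers for stronger inhibition:
compound 1 `O=C(O)c1cc(CCCCNS(=O)(=O)c2ccccc2)c2cccccc1-2` gives 570 nM
compound 2 `O=C(O)c1cc(CCCCCCCNS(=O)(=O)c2ccccc2)c2cccccc1-2` gives 18 nM
compound 3 `CC(C)c1ccc2c(CCCCCCCNS(=O)(=O)c3ccccc3)cc(C(=O)O)c-2cc1` gives 120 nM

Compound 1 carries the highest number of the three; compound 2 the lowest. The difference between the cores of compound 1 and compound 2 is not broken down here.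

Compound 3 arises from compound 2 by isopropyl in place of hydrogen on an aromatic carbon. That change brings a 6.7-fold higher number from compound 2 to compound 3 (0.82 log units; beyond the scatter).

Compound 4 `CC(C)c1cccc2c(CCCCNS(=O)(=O)c3ccccc3)cc(C(=O)O)c-2c1` is not yet measured. It arises from compound 1 by isopropyl in place of hydrogen on an aromatic carbon, the same change as from compound 2 to compound 3. On the strength of that single earlier step, compound 4 is expected to show a 5.6-fold higher number from compound 1 to compound 4 (0.75 log units; beyond the scatter), as a working estimate.

The estimate for compound 4 in this assay is therefore 3200 nM, expected to lie between 1100 nM and 9500 nM.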

Compound 4, half-maximal inhibitory concentration: 3100 nM
Compound 4: the middle estimate sits 1.0-fold (0.01 log units) above what was measured, and the stated range covers the measured number.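

In this assay, isopropyl in place of hydrogen on an aromatic carbon brings a 5.4-fold higher number from compound 1 to compound 4 (0.74 log units; beyond the scatter), and the change carries from one core to the other at much the same size: the same change on two cores in this assay, a 6.7-fold higher number (0.82 log units; beyond the scatter) from compound 2 to compound 3 and a 5.4-fold higher number (0.74 log units; beyond the scatter) from compound 1 to compound 4, 1.2-fold (0.09 log units) apart, within the scatter of two such steps

This agreement rests on two pairs of compounds, so it supports carrying the change between the cores of compound 1 and compound 2 but sets no rule for other cores in the series. It also gives no cause for the weaker inhibition seen in both steps.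

The compounds shown leave open how methyl, chlorine or an amine would compare with isopropyl on the seven-membered ring. They also leave open whether the same step would hold with an amide in place of the carboxylic acid.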